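Adding fluoro: from compound 3 to compound 4

The source may report more compounds than this note shows. Statements on the series, on what has been measured and on what is new or still open speak of the compounds shown alone.

Measured in a functional assay on MCF7 cells (Homo sapiens) for inhibition, in the presence of a further agent that is not named here; a lower number here means a stronger inhibitor, a higher number a weaker inhibitor:
- compound 1 `Nc1ccc(-c2cc(=O)c3c(N)c(F)cc(F)c3o2)cc1F`: 25 nM
- compound 2 `Nc1ccc(-c2cc(=O)c3c(N)ccc(F)c3o2)cc1`: 170 nM
- compound 3 `Nc1ccc(-c2cc(=O)c3c(N)c(F)ccc3o2)cc1`: 130 nM

Compound 3 stands within the scatter of compound 2, and the two values show no real separation. Compound 1 gives 25 nM, a lower number than both, and its gap to each of them lies outside the scatter.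

The next compound is compound 4 `Nc1ccc(-c2cc(=O)c3c(N)c(F)cc(F)c3o2)cc1`. It has fluoro in place of hydrogen on an aromatic carbon, para to an amino group: fluoro in place of hydrogen on an aromatic carbon.

For the measured compounds named here, no measured pair differs in one place only, so the size of this step is not directly supported. The core of compound 4 also occurs in compound 1, at 25 nM, which suggests a move toward a lower number in this assay. The expected change is modest, a 2.6-fold lower number from compound 3 to compound 4 (0.41 log units; beyond the scatter), and may only just clear the scatter. For compound 4 the estimated value is 50 nM, with an expected range of 20 nM to 120 nM.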

Compound 4, half-maximal inhibitory concentration: 46 nM
Estimate against measurement, compound 4: 1.1-fold (0.04 log units) above, and the stated range covers the measured number.
By their numbers in this assay, from the lowest: compounds 1 and 4 (each within the scatter of the next); then compounds 3 and 2 (each within the scatter of the next).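

In this assay the fluoro on the aromatic carbon para to an amino group brings a real gain (in this step a 2.8-fold lower number from compound 3 to compound 4 (0.45 log units; beyond the scatter)), and the other fluoro of the core also brings one (a 3.7-fold lower number from compound 2 to compound 4 (0.57 log units; beyond the scatter)), so the core with both fluoro groups gives a lower number than either core with one. The extra fluoro of compound 1 adds nothing that can be separated here, since the step (a 1.8-fold higher number from compound 1 to compound 4 (0.26 log units; within the scatter)) stays within the scatter. No measurement at hand gives a cause for these steps.

From the compounds shown here alone, it remains open whether chloro, methyl or methoxy on this same carbon would match fluoro. The compounds shown also do not tell whether either amino group could give way to a hydroxyl or an amide.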